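The source may hold more compounds than are shown below. What is called first, only, known or untested is meant among the compounds shown, and "the series" means these compounds.

Measured compounds in this series:
compound 1, `O=C(Nc1ncc(Cc2ccc(F)cc2)s1)c1ccc(Br)cc1`: > 50000 nM
compound 2, `CC(C)(C)OC(=O)Nc1ncc(C(Oc2ccc(F)c(Cl)c2)c2ccc(Cl)cc2)s1`: > 50000 nM
compound 3, `COCCCNc1ncc(C(Oc2ccc3cc(Br)ccc3c2)c2ccc(Cl)cc2)s1`: "not toxic" (no number reported)

In an ADME assay on HepG2 2.2.15 cells (Homo sapiens) for cytotoxicity (on this read-out lower numbers stand for higher toxicity in this test and higher numbers for lower toxicity in this test), compound 1 gives > 50000 nM, which is a limit of the test and not a number. Compound 2 also ends at a limit, > 50000 nM. Compound 3 is recorded only as "not toxic" (no number reported), without a number. Compound 3 therefore has no single value to stand on; its neighbours in the series define (the limit of > 50000 nM in this assay, at which 2 of the 3 values shown sit), and compound 3 sits in the same region as far as the wording goes.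

The next compound, compound 4 `Cc1ccc(C)c(S(=O)(=O)Nc2ncc(C(Oc3ccc4cc(Br)ccc4c3)c3ccc(Cl)cc3)s2)c1`, is not yet measured. It differs from compound 3 by one change: (2,5-dimethylphenyl)sulfonyl in place of 3-methoxypropyl on a nitrogen on an aromatic ring. Going by the values given here, no step between measured compounds exists to guide the size of this change. Given that every measured value in this assay either sits at the limit or is reported as non-toxic, no step beyond the scatter is expected in this assay , in either direction. Compound 4 is expected to give an estimated 50000 nM, with a range from 20000 nM to 100000 nM, most likely reported again as a limit rather than a number.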

Compound 4, half-maximal cytotoxic concentration: > 50000 nM
Compound 4 gave a limit, no number (the forecaster's own chance of this, stated with the estimate: 75%); the middle value sits exactly at the limit.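

In this assay compound 4 gives > 50000 nM, a limit of the test and not a number. Compound 3 is recorded only as "not toxic", so no step can be read between compound 3 and compound 4. The compounds shown leave open at what concentration any of them becomes toxic: the limit of > 50000 nM in this assay, at which 3 of the 4 values shown sit.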